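Swapping 4-methoxyphenyl for 2-chloropyridin-3-yl on the shared core

This account rests on a few compounds, and the source may have more. Where it says the series, first, only, none or still open, it means among the compounds named here.

Measured so far in a functional assay on A-431 cells (Homo sapiens) for cytotoxicity, read by MTT assay, with a stated time of 24 h; on this read-out lower numbers stand for stronger inhibition and higher numbers for weaker inhibition 
Compound 1 `COc1ccc(/C=C\C(=O)O)c(OCc2cn(-c3ccccc3F)nn2)c1CC=C(C)C` gives 12400 nM 
Compound 2 `COc1ccc(/C=C\C(=O)O)c(OCc2cn(-c3ccccc3)nn2)c1CC=C(C)C` gives 21200 nM 
Compound 3 `COc1ccc(-n2cc(COc3c(/C=C\C(=O)O)ccc(OC)c3CC=C(C)C)nn2)cc1` gives "not determined" (no result reported) 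

Compound 3 therefore offers no number to start from. The step to compound 4 `COc1ccc(/C=C\C(=O)O)c(OCc2cn(-c3cccnc3Cl)nn2)c1CC=C(C)C` is 2-chloropyridin-3-yl in place of 4-methoxyphenyl on an aromatic nitrogen and puts 2-chloropyridin-3-yl in place of 4-methoxyphenyl on an aromatic nitrogen. Within the data shown here, only one measured step bears on this, a 1.7-fold higher number from compound 1 to compound 2 (0.23 log units; within the scatter) for hydrogen in place of fluoro on an aromatic carbon. Without a value for compound 3, no size or direction can be set for the step itself, and compound 4 is expected to fall within the scatter of its two measured neighbours. The estimate for compound 4 is 15000 nM as the expected value, with an expected range from 6000 nM to 35000 nM around it.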

Compound 4, half-maximal inhibitory concentration: 32600 nM
Beside the measured number, compound 4's estimate is 2.2-fold (0.34 log units) below it; measured number inside the range.
By their numbers in this assay, from the lowest: compounds 1, 2 and 4 (each within the scatter of the next, the first and the last beyond it).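

In this assay, among these compounds, 2-chloropyridin-3-yl gives the first reading of a ring with a hetero atom on this aromatic nitrogen, and a 1.5-fold higher number from compound 2 to compound 4 (0.19 log units; within the scatter) leaves it level with phenyl. Against 2-fluorophenyl, a 2.6-fold higher number from compound 1 to compound 4 (0.42 log units; beyond the scatter) is the first step in the series to pass the scatter, though only modestly. The step from compound 3 cannot be read, and nothing at hand accounts for these numbers. The compounds shown leave open how a saturated cyclohexyl ring would read on this nitrogen. They also leave open whether an amine on the pyridine ring would shift the number.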